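Benzyl ring exchange: from compound 3 to compound 4

The source may report more compounds than this note shows. Statements on the series, on what has been measured and on what is new or still open speak of the compounds shown alone.

Three compounds share one core and differ only in the group on a saturated chain carbon bound to an aromatic carbon. In an in vitro functional assay on cells for agonist activity at Bombesin receptor subtype-3 (Homo sapiens), read by luminescence and calcium flux (on this read-out higher numbers stand for an effect only at larger amounts of compound and lower numbers for an effect already at smaller amounts), compound 1 `O=C(O)c1ccccc1-c1ccc(CCc2ncc(CC3CCOCC3)[nH]2)cc1` gives 338 nM, compound 2 `O=C(O)c1ccccc1-c1ccc(CCc2ncc(CC3CCCC3)[nH]2)cc1` gives 133 nM, and compound 3 `O=C(O)c1ccccc1-c1ccc(CCc2ncc(Cc3ccccc3F)[nH]2)cc1` gives 177 nM. Compound 3 holds the second highest of the three numbers. Of the steps, only a 2.5-fold lower number from compound 1 to compound 2 (0.41 log units; beyond the scatter) reaches beyond the scatter, while a 1.9-fold lower number from compound 1 to compound 3 (0.28 log units; within the scatter) and a 1.3-fold higher number from compound 2 to compound 3 (0.12 log units; within the scatter) stay within the usual spread.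

Compound 4 `Cc1cccc(Cc2cnc(CCc3ccc(-c4ccccc4C(=O)O)cc3)[nH]2)c1` differs from compound 3 by 3-methylphenyl in place of 2-fluorophenyl on a saturated chain carbon bound to an aromatic carbon. Among the compounds with values here, no measured step compares two substituted aromatic rings at this place; the steps that bear on it are the three above, which show oxan-4-yl, cyclopentyl and 2-fluorophenyl at this position sitting in a narrow band. An exchange of one aromatic ring for another is therefore expected to give no step beyond the scatter in this assay. Compound 4 is estimated at 170 nM, with a range of 70 nM to 420 nM, which means an expected step of a 1.0-fold lower number from compound 3 to compound 4 (0.02 log units; within the scatter).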

Compound 4, half-maximal effective concentration: 4310 nM
For compound 4 the middle estimate is 25-fold (1.40 log units) below the measured one, outside the stated range (above it).
By their numbers in this assay, from the lowest: compounds 2, 3 and 1 (each within the scatter of the next, the first and the last beyond it); then compound 4.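

In this assay, within the data shown here, this position proves far less permissive than the earlier compounds suggested, as 3-methylphenyl stands apart with a 24-fold higher number from compound 3 to compound 4 (1.39 log units; beyond the scatter) and a 32-fold higher number from compound 2 to compound 4 (1.51 log units; beyond the scatter) and also a 13-fold higher number from compound 1 to compound 4 (1.11 log units; beyond the scatter) against the earlier groups. The large first step comes from an exchange that leaves the heavy-atom count, the six-membered aromatic ring of carbon only, the absence of hydrogen-bond donors and acceptors, and the lack of net charge all unchanged, so these counted features do not separate 2-fluorophenyl from 3-methylphenyl. Nothing on hand accounts for the size of this step.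

Still open, as far as these compounds go, is whether the step follows the methyl group itself or its place on the ring, and 2-methylphenyl and 3-fluorophenyl at this position would separate the two. Unsubstituted phenyl would show how each substituent compares with the bare ring.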